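The source may report more compounds than this note shows. Statements on the series, on what has been measured and on what is new or still open speak of the compounds shown alone.

Compound 1 `C=C1CC[C@@H]2[C@](C)(CCC[C@]2(C)C(=O)OC)[C@H]1CCc1ccc2c(OC)ccc(OC)c2c1` and compound 2 `C=C1CC[C@@H]2[C@](C)(CCC[C@]2(C)C(=O)OC)[C@H]1CCc1ccc2c(OCc3ccccc3)ccc(OCc3ccccc3)c2c1` share a core whose difference is not broken down here. In a functional assay on A549 cells (Homo sapiens) for cytotoxicity, read by sulforhodamine B assay, with a stated time of 72 h (on this read-out higher numbers stand for weaker inhibition of growth and lower numbers for stronger inhibition of growth), compound 1 gives only a limit, > 6700 nM. Compound 2 also gives only a limit, > 5000 nM. Compound 3 `C=C1[C@H](O)C[C@@H]2[C@](C)(CCC[C@]2(C)C(=O)OC)[C@H]1CCc1ccc2c(OCc3ccccc3)ccc(OCc3ccccc3)c2c1` differs from compound 2 by hydroxy in place of hydrogen on a saturated ring carbon. Compound 3 likewise gives only a limit, > 4900 nM. The step that the two limits leave unreadable from compound 2 to compound 3 cannot be sized, as the limit of > 5000 nM in this assay, at which 1 of the 3 values shown sits, and the limit of > 4900 nM in this assay, at which 1 of the 3 values shown sits, show.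

Compound 4 `C=C1CC[C@@H]2[C@](C)(CCC[C@]2(C)C(=O)OC)[C@]1(O)CCc1ccc2c(OC)ccc(OC)c2c1` differs from compound 1 by hydroxy in place of hydrogen on a saturated ring carbon. This is the same kind of change as in compound 3, but at a different place: in compound 4 the hydroxy stands next to the ring atom that bears a fused ring and next to the ring atom that bears a methyl group, whereas in compound 3 it stands two ring bonds from the ring atom that bears a fused ring and two ring bonds from the ring atom that bears a large group. Since the earlier step is unreadable, the expected step that the limit leaves unreadable from compound 1 to compound 4 rests only on compound 1 sitting at the limit > 6700 nM. Compound 4 is therefore expected to give about 9000 nM, most likely again only a limit, between 2500 nM and 40000 nM.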

Compound 4, concentration for 50% growth inhibition: > 21500 nM
Compound 4 ended at the assay's limit; the forecaster's own chance of this, stated with the estimate: 75%; middle value at least 2.3-fold (0.37 log units) from the limit.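

In this assay, for the compounds shown here, compound 1 and compound 4 both give only a limit, so no step between them can be read. The compounds shown leave open whether hydroxy in place of hydrogen changes growth inhibition at all.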